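Stripping the hydroxyls from a side chain

This account rests on a few compounds, and the source may have more. Where it says the series, first, only, none or still open, it means among the compounds named here.

Compound 1 `Cn1ncc(Cl)c1-c1cc(C(=O)N[C@@H]2CN[C@H](CCN3CCC(O)CC3)C[C@H]2c2ccc(Cl)c(Cl)c2)oc1Cl`: 5.99 nM
Compound 2 `Cn1ncc(Cl)c1-c1cc(C(=O)N[C@@H]2CN[C@H](CC(=O)NCC(O)CO)C[C@H]2c2ccc(Cl)c(Cl)c2)oc1Cl`: 3.13 nM
Compound 3 `Cn1ncc(Cl)c1-c1cc(C(=O)N[C@@H]2CN[C@H](CC(O)CO)C[C@H]2c2ccc(Cl)c(Cl)c2)oc1Cl`: 3.79 nM

In an assay for inhibition of RAC-alpha serine/threonine-protein kinase (Homo sapiens), read by HTRF, with a stated time of 1 h (on this read-out higher numbers stand for weaker inhibition and lower numbers for stronger inhibition), compound 3 gives the second highest of the three numbers, but the gaps to its neighbours, a 1.2-fold higher number from compound 2 to compound 3 (0.08 log units; within the scatter) and a 1.6-fold lower number from compound 1 to compound 3 (0.20 log units; within the scatter), lie within the scatter, so no ranking among the three holds. Compound 4 `CCC[C@@H]1C[C@@H](c2ccc(Cl)c(Cl)c2)[C@H](NC(=O)c2cc(-c3c(Cl)cnn3C)c(Cl)o2)CN1` differs from compound 3 in one place: ethyl in place of 1,2-dihydroxyethyl on a saturated chain carbon bound to a saturated ring carbon. Every measured step, including a 1.9-fold lower number from compound 1 to compound 2 (0.28 log units; within the scatter), swapped one hydroxyl-bearing group for another and stayed within the scatter; none removed the hydroxyls altogether, so they bear on this change only loosely. A small rise in the number is expected for compound 4, a step of a 1.8-fold higher number from compound 3 to compound 4 (0.27 log units; within the scatter), with wide uncertainty. Compound 4 is therefore estimated at 7 nM, between 2.5 nM and 25 nM.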

Compound 4, half-maximal inhibitory concentration: 10.4 nM
For compound 4 the middle estimate is 1.5-fold (0.17 log units) below the measured one; the measured number falls inside the stated range.
By their numbers in this assay, from the lowest: compounds 2, 3, 1 and 4 (each within the scatter of the next, the first and the last beyond it).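

Among the compounds shown here, replacing the hydroxyl-bearing groups with the bare ethyl chain gives the first steps beyond the scatter, with a 2.7-fold higher number from compound 3 to compound 4 (0.44 log units; beyond the scatter) and a 3.3-fold higher number from compound 2 to compound 4 (0.52 log units; beyond the scatter) both modest. The side chain of compound 1 goes against this pattern, as a 1.7-fold higher number from compound 1 to compound 4 (0.24 log units; within the scatter) stays within the scatter, so the effect of the change depends on which group leaves. No measurement here explains these steps.

As far as these compounds go, whether one hydroxyl on the ethyl group would match the diol remains open. So does how an amine or a carboxylic acid would behave on this saturated chain carbon.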